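The compounds below may be only part of what the source reports. "The series", "measured", "known", "first", "only" and "open" are said of these compounds alone.

Compound 1 `CCn1ccnc1-c1cccc(Cl)c1CCc1cc(Br)ccc1OC` holds the second highest of the three numbers in a functional assay on HEK293 cells (Homo sapiens), read by cAMP accumulation (on this read-out higher numbers stand for weaker inhibition and lower numbers for stronger inhibition), at 1800 nM. Compound 2 `CCCn1ccnc1-c1cccc(Cl)c1CCc1cc(Br)ccc1OC` gives 1900 nM and compound 3 `COc1ccc(Br)cc1CCc1c(Cl)cccc1-c1nccn1CC1CC1` gives 1700 nM; the steps of a 1.1-fold higher number from compound 1 to compound 2 (0.02 log units; within the scatter), a 1.1-fold lower number from compound 1 to compound 3 (0.02 log units; within the scatter) and a 1.1-fold lower number from compound 2 to compound 3 (0.05 log units; within the scatter) all sit within the scatter. Each of those steps varies the group on the saturated chain carbon bound to the aromatic nitrogen, and none of them moves the read-out. Compound 4 `COc1ccc(Br)cc1CCc1c(Cl)cccc1-c1ncc2n1CCCC2` differs from compound 1 by a group of 9 heavy atoms (7 carbon, 2 nitrogen; one five-membered aromatic ring with 2 hetero atoms, one six-membered non-aromatic ring with 1 hetero atom) in place of a group of 7 heavy atoms (5 carbon, 2 nitrogen; one five-membered aromatic ring with 2 hetero atoms), on an aromatic carbon: the chain on that aromatic nitrogen is closed into a six-membered non-aromatic ring with 1 hetero atom fused to the five-membered aromatic ring with 2 hetero atoms. The three measured steps bear on this only in showing that changes at that nitrogen have left this assay unmoved; a fused ring is a larger change than any of them, so no step beyond the scatter is expected in either direction, but the range is set wide. Compound 4 is therefore expected close to compound 1, at an estimated 1600 nM (range 600 nM to 4500 nM), a step of a 1.1-fold lower number from compound 1 to compound 4 (0.05 log units; within the scatter).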

Compound 4, half-maximal inhibitory concentration: 590 nM
Compound 4: middle estimate off by 2.7-fold (0.43 log units), on the high side; measured number below the stated range.
By their numbers in this assay, from the lowest: compound 4; then compounds 3, 1 and 2 (each within the scatter of the next).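

In this assay, for the compounds shown here, closing the chain on the aromatic nitrogen into a fused six-membered non-aromatic ring gives the only steps beyond the scatter in this set: a 3.1-fold lower number from compound 1 to compound 4 (0.48 log units; beyond the scatter), a 3.2-fold lower number from compound 2 to compound 4 (0.51 log units; beyond the scatter) and a 2.9-fold lower number from compound 3 to compound 4 (0.46 log units; beyond the scatter). The group in compound 3 has the same heavy-atom count as the fused group in compound 4, so this count alone does not track the step; the two groups differ in how those atoms are arranged, with a cyclopropyl on the chain in compound 3 and a fused ring in compound 4. Nothing available gives a reason for the step.

As far as these compounds go, whether the step depends on ring size remains open, and a fused five-membered or seven-membered ring would bear on this. Also open, from the compounds shown here alone, is how the number responds to a hydroxyl or an amine on the fused ring.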